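A few compounds are considered here, and "the series" means these few. Any claim that something is new, unique, unknown or untested is made for them only; others in the source may bear on it.

Compounds measured in an ADME assay on microsomes from liver (Homo sapiens), read by LC-MS, using NADPH, with a stated time of 30 min, tested at 1 uM; a higher number here means that more of the compound is left, a lower number that less of the compound is left:
- compound 1, `C[C@H](Nc1ncnc(N)c1C#N)c1cc(=O)n2cc(F)ccc2c1-c1ccccc1`: 90%
- compound 2, `C[C@H](Nc1ncnc(N)c1C#N)c1cc(=O)n2cc(F)ccc2c1-c1cccc(F)c1`: 87%

Compound 2 holds the lower of the two numbers, but the step of a number 3 percentage points lower from compound 1 to compound 2 (within the scatter) lies within the scatter. Compound 3, `C[C@H](Nc1ncnc(N)c1C#N)c1cc(=O)n2cc(F)ccc2c1-c1cc(F)cc(F)c1`, is not yet measured. It differs from compound 2 by fluoro in place of hydrogen on an aromatic carbon, meta to a fluoro group. Within the data shown here, the only bearing step is a number 3 percentage points lower from compound 1 to compound 2 (within the scatter), the same kind of change one ring position away, and it gave no step beyond the scatter. For compound 3 in this assay a change of about a number 2 percentage points lower from compound 2 to compound 3 (within the scatter) is expected, again within the scatter. The estimate for compound 3 is 85%, range 70% to 97%.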

Compound 3, percent of the compound remaining: 91%
For compound 3 the middle estimate is 6 percentage points below the measured one; the range from low to high includes it.
By their numbers in this assay, from the lowest: compounds 2, 1 and 3 (each within the scatter of the next).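

In this assay, adding a second fluoro to the ring, meta to the first, gives a number 4 percentage points higher from compound 2 to compound 3 (within the scatter) and the whole change from phenyl to 3,5-difluorophenyl gives a number 1 percentage points higher from compound 1 to compound 3 (within the scatter). The ring therefore carries two fluoro groups with the number still within the scatter of the unsubstituted phenyl, so one fluoro and two fluoro groups cannot be told apart here. Nothing available bears on the reason for these numbers.

Still open, from the compounds shown here alone, is whether a group other than fluoro at this ring position, such as methoxy or an amine, would stay within the scatter of these three compounds.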